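Chloro for methoxy, tested on two chain lengths

This account rests on a few compounds, and the source may have more. Where it says the series, first, only, none or still open, it means among the compounds named here.

Three compounds have been measured:

Compound 1, `COc1ccccc1N1CCN(CCCn2ncc(N3CCN(C(=O)c4ccco4)CC3)c(Cl)c2=O)CC1`, gives 20.4 nM in an assay on cell membranes for binding affinity to Adrenergic receptor alpha-1 (Rattus norvegicus), read by radioligand binding; a higher number here means a weaker inhibitor, a lower number a stronger inhibitor.
Compound 2, `O=C(c1ccco1)N1CCN(c2cnn(CCCN3CCN(c4ccccc4Cl)CC3)c(=O)c2Cl)CC1`, gives 3.5 nM in this assay.
Compound 3, `COc1ccccc1N1CCN(CCCCn2ncc(N3CCN(C(=O)c4ccco4)CC3)c(Cl)c2=O)CC1`, gives 33.5 nM in this assay.

Compounds 1 and 2 share a core and differ in one place: chloro in place of methoxy on an aromatic carbon. That single change gave a 5.8-fold lower number from compound 1 to compound 2 (0.77 log units; beyond the scatter). Compound 3 carries the same methoxy group as compound 1, but its core differs from the core of compound 1; the difference between the two cores is not broken down here. Among the three measured compounds, compound 3 has the highest number, yet its gap to compound 1 lies within the usual scatter, so the two cannot be ranked against each other. Its gap to compound 2 lies beyond the scatter.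

Compound 4, `O=C(c1ccco1)N1CCN(c2cnn(CCCCN3CCN(c4ccccc4Cl)CC3)c(=O)c2Cl)CC1`, has not yet been measured. It differs from compound 3 by chloro in place of methoxy on an aromatic carbon. Going by the values given here, this is the same change as the one from compound 1 to compound 2, and it sits at the same kind of place in both pairs. Starting from compound 3, the step is expected to be a 4.8-fold lower number from compound 3 to compound 4 (0.68 log units; beyond the scatter), because the same change gave a 5.8-fold lower number from compound 1 to compound 2 (0.77 log units; beyond the scatter). Whether a different core carries the effect equally cannot be known from these data, so the expected step is set a little smaller than the one already seen. Compound 4 is therefore expected to give about 7 nM, with a likely range from 2.5 nM to 20 nM.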

Compound 4, inhibition constant: 19 nM
For compound 4 the middle estimate is 2.7-fold (0.43 log units) below the measured one; the range from low to high includes it.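

Moving from 2-methoxyphenyl to 2-chlorophenyl on the second core gave a 1.8-fold lower number from compound 3 to compound 4 (0.25 log units; within the scatter) in this assay, so on that core the two compounds cannot be ranked against each other. The same change therefore did not carry over at the same size, and the two steps differ by more than repeated measurements would explain: the same change on two cores in this assay, a 5.8-fold lower number (0.77 log units; beyond the scatter) from compound 1 to compound 2 and a 1.8-fold lower number (0.25 log units; within the scatter) from compound 3 to compound 4, 3.3-fold (0.52 log units) apart, beyond the scatter of two such steps. Going by these compounds alone, this shows that, in this series, a step seen on one core is not a safe guide to its size on another, but with only two pairs it gives no general rule, does not show which difference between the cores matters, and does not prove that the change has no effect at all on the core of compound 3.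

The compounds shown leave open whether a fluoro or a methyl group at the same place on the aromatic ring would follow the chloro group, giving a clear step on one core and none that can be read on the other. They also leave open whether a core with a longer chain would show a step closer to the larger one, the smaller one, or neither.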